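A few compounds are considered here, and "the series" means these few. Any claim that something is new, unique, unknown or untested is made for them only; others in the source may bear on it.

Measured in an ADME assay on the whole organism (Rattus norvegicus) for pharmacokinetics, using cassette dosing, at a dose of 1 mg/kg by the oral route; on this read-out higher numbers stand for higher oral bioavailability and lower numbers for lower oral bioavailability:
- compound 1 `Cc1ccc(Cn2c(=O)n(C[C@H](C)C(=O)O)c(=O)[nH]/c2=N\c2ccc(OC(C)C)c(Cl)c2)cc1`: 73.1%
- compound 2 `C[C@@H](Cn1c(=O)[nH]/c(=N\c2ccc(Oc3cncc(F)c3)cc2)n(Cc2ccc(Cl)cc2)c1=O)C(=O)O`: 74.3%

In this pair, compound 2 lies within the scatter of compound 1, so neither stands apart on these numbers. Compound 3 `C[C@@H](Cn1c(=O)[nH]/c(=N\c2ccc(Oc3ccsn3)cc2)n(Cc2ccc(Cl)cc2)c1=O)C(=O)O` differs from compound 2 by one change, 1,2-thiazol-3-yl in place of 5-fluoropyridin-3-yl on an oxygen on an aromatic ring. Among the compounds with values here, no measured pair shows what such a change does in this assay, so no shift beyond the scatter is expected, though the uncertainty is wide. The estimated change is a number 6.3 percentage points lower from compound 2 to compound 3 (within the scatter). For compound 3 the expected value is 68%, with an estimated range of 42% to 88%.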

Compound 3, oral bioavailability: 87.6%
Compound 3: middle estimate off by 19.6 percentage points, on the low side; the measured number falls inside the stated range.
By their numbers in this assay, from the lowest: compounds 1 and 2 (each within the scatter of the next); then compound 3.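

At this position, on an oxygen on an aromatic ring, the choice of heteroaromatic ring clearly matters in this assay: 1,2-thiazol-3-yl in place of 5-fluoropyridin-3-yl gives a number 13.3 percentage points higher from compound 2 to compound 3 (beyond the scatter). The smaller, five-membered ring is thus tolerated here, and oral bioavailability gains from the swap. Nothing shown accounts for this gain.

Going by these compounds, it remains open whether the step belongs to the five-membered ring itself or to the loss of the fluorine. A plain pyridin-3-yl or a 1,3-thiazol-2-yl on the same oxygen would help separate these two readings.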